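Acetamide to Dimethylurea on a Shared Biphenyl-Free Core

The source may report more compounds than this note shows. Statements on the series, on what has been measured and on what is new or still open speak of the compounds shown alone.

Going by the values given here, compound 2 `CCOc1ccc(-c2cccc(NC(C)=O)c2)cc1` is the only compound with a definite number: in an assay on COS-7 cells for inhibition of patatin-like phospholipase domain-containing protein 2 (Mus musculus) (on this read-out higher numbers stand for weaker inhibition and lower numbers for stronger inhibition), compound 2 gives 200000 nM. Compound 1 `CCOc1ccc(-c2cccc(C(=O)NC)c2)cc1` shows only a limit of the assay in this assay, namely > 200000 nM. Among the compounds with values here, the step of a number no higher from compound 1 to compound 2 (the limit leaves the size open) is the sole measured comparison, and the limit of > 200000 nM in this assay, at which 1 of the 2 values shown sits, leaves its size unreadable. Compound 3 `CCOc1ccc(-c2cccc(NC(=O)N(C)C)c2)cc1` differs from compound 2 by dimethylamino in place of methyl on a carbonyl carbon. Within the data shown here, no measured step touches a carbonyl carbon. The expected move no change at the digits printed from compound 2 to compound 3 (within the scatter) is none beyond the scatter. Compound 3 is estimated at 200000 nM, within 60000 nM to 300000 nM.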

Compound 3, half-maximal inhibitory concentration: 70000 nM
Compound 3: the middle estimate sits 2.9-fold (0.46 log units) above what was measured; the measured number falls inside the stated range.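

In this assay, going by these compounds alone, the carbonyl carbon responds to this change: dimethylamino in place of methyl gives a 2.9-fold lower number from compound 2 to compound 3 (0.46 log units; beyond the scatter) and so provides the first step here with a readable size. (Dimethylcarbamoyl)amino in place of methylcarbamoyl on the aromatic carbon gives an at least 2.8-fold lower number from compound 1 to compound 3 (0.45 log units; beyond the scatter) on the same read-out. Going by these compounds, the size of that second step stays open, as the value for compound 1 is a limit of the assay: the limit of > 200000 nM in this assay, at which 1 of the 3 values shown sits. The compounds shown leave open how a methylamino, a diethylamino or a methoxy group on that carbonyl carbon would read.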